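From 4-methylphenyl to 2-fluorophenyl on a shared core

The source may hold more compounds than are shown below. What is called first, only, known or untested is meant among the compounds shown, and "the series" means these compounds.

Three compounds have been measured in a functional assay on MCF-10A cells (Homo sapiens) for antiproliferative activity, with a stated time of 48 h (a lower number here means that less compound is needed, a higher number that more compound is needed for the effect), so far:
compound 1 `COc1ccc2nc(C)cc(NCc3ccncc3)c2c1` gives 41600 nM
compound 2 `COc1ccc2nc(C)cc(NCc3cccnc3)c2c1` gives 49300 nM
compound 3 `COc1ccc2nc(C)cc(NCc3ccc(C)cc3)c2c1` gives 22400 nM

Compound 3 stands close to both others, with a 1.9-fold lower number from compound 1 to compound 3 (0.27 log units; within the scatter) and a 2.2-fold lower number from compound 2 to compound 3 (0.34 log units; beyond the scatter) as the steps that reach it. Compound 4 `COc1ccc2nc(C)cc(NCc3ccccc3F)c2c1` has 2-fluorophenyl in place of 4-methylphenyl on a saturated chain carbon bound to a nitrogen on an aromatic ring. Going by the values given here, no measured step makes this exchange. The nearest steps change the same group, and besides those two there is only a 1.2-fold higher number from compound 1 to compound 2 (0.07 log units; within the scatter) to go on. All are small, so only a small shift is expected in this assay. The expected change is a 1.3-fold higher number from compound 3 to compound 4 (0.13 log units; within the scatter) and would leave the number near the others. For compound 4 the estimate is 30000 nM with an expected range from 15000 nM to 60000 nM in this read-out.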

Compound 4, half-maximal effective concentration: 17000 nM
For compound 4 the middle estimate is 1.8-fold (0.25 log units) above the measured one; low and high end bracket the measured number.
By their numbers in this assay, from the lowest: compounds 4, 3, 1 and 2 (each within the scatter of the next, the first and the last beyond it).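

At this place, on a saturated chain carbon bound to a nitrogen on an aromatic ring, 2-fluorophenyl and 4-methylphenyl cannot be told apart in this assay, with a 1.3-fold lower number from compound 3 to compound 4 (0.12 log units; within the scatter) as the step. Yet 2-fluorophenyl clears the scatter against both pyridinyl groups, with a 2.4-fold lower number from compound 1 to compound 4 (0.39 log units; beyond the scatter) and a 2.9-fold lower number from compound 2 to compound 4 (0.46 log units; beyond the scatter) as its steps, whereas 4-methylphenyl did so only against pyridin-3-yl. No evidence on why is available here. Still open, going by these compounds, is what plain phenyl would give against 2-fluorophenyl. An amine or carboxylic acid on the ring, or a longer chain, might also move the number further.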